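A few compounds are considered here, and "the series" means these few. Any claim that something is new, unique, unknown or untested is made for them only; others in the source may bear on it.

Measured so far in an ADME assay on PA-1 cells (Homo sapiens) for cytotoxicity, read by MTT assay, with a stated time of 72 h; on this read-out lower numbers stand for stronger inhibition and higher numbers for weaker inhibition:
- Compound 1 `COc1ccc(C2=C(c3cc(OC)c(OC)c(OC)c3)C(=O)C(OC(C)=O)C2)cc1`: < 1 ug/mL
- Compound 2 `COc1ccc(C2=C(c3cc(OC)c(OC)c(OC)c3)C(=O)C(OC(C)=O)C2)cc1F`: > 100 ug/mL

Both values are limits of the assay, not numbers. Compound 2 stands at the weak end of the two.

Compound 3 `COc1ccc(C2=C(c3cc(OC)c(OC)c(OC)c3)C(=O)C(OC(C)=O)C2)cc1O` differs from it in one group: hydroxy in place of fluoro on an aromatic carbon. Among the compounds with values here, the one measured step on this aromatic carbon, an at least 100-fold higher number from compound 1 to compound 2 (2.00 log units; beyond the scatter), was large, so a change here can matter in this assay. Within the data shown here, no hydroxy compound has been measured yet, so the expectation is loose: a sizeable move towards stronger inhibition. The expected change is an at least 20-fold lower number from compound 2 to compound 3 (1.30 log units; beyond the scatter). Compound 3 is estimated at 5 ug/mL, with an expected range of 0.5 ug/mL to 100 ug/mL.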

Compound 3, half-maximal inhibitory concentration: 6 ug/mL
Compound 3: the middle estimate sits 1.2-fold (0.08 log units) below what was measured, within the range that was stated.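

In this assay, this aromatic carbon does not reject every replacement for hydrogen equally: hydroxy restores much of what fluoro lost, an at least 16-fold lower number from compound 2 to compound 3 (1.22 log units; beyond the scatter). Hydroxy still does not match hydrogen, an at least 6.0-fold higher number from compound 1 to compound 3 (0.77 log units; beyond the scatter). Both steps are bounds rather than exact sizes, since compound 1 and compound 2 each stand at a limit of the assay, not at a number. From the compounds shown here alone, how an amine or a carboxylic acid would behave on this carbon remains open, as does the true size of the gap between hydrogen and hydroxy.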